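This account rests on a few compounds, and the source may have more. Where it says the series, first, only, none or still open, it means among the compounds named here.

Compound 1 `C#CCNC(=O)/C=C/c1cnc(Nc2ccc(C#N)cc2)nc1Oc1c(C)cc(C#N)cc1C` is known in an ADME assay on TZM cells (Homo sapiens) for cytotoxicity, with a stated time of 1 days (a higher number here means that more compound is tolerated, a lower number that less compound is tolerated), only as a limit, giving > 222 nM. Compound 2 `COCCNC(=O)/C=C/c1cnc(Nc2ccc(C#N)cc2)nc1Oc1c(C)cc(C#N)cc1C` likewise returns a limit, > 213 nM. The step that the two limits leave unreadable from compound 1 to compound 2 therefore cannot be read as a number. Compound 3 `Cc1cc(C#N)cc(C)c1Oc1nc(Nc2ccc(C#N)cc2)ncc1/C=C/C(=O)NC1CCN(S(=O)(=O)C(F)(F)F)CC1` also stops at a limit, > 160 nM. So compound 1 stands among three values that are all limits, as the limit of > 160 nM in this assay, at which 1 of the 3 values shown sits, the limit of > 213 nM in this assay, at which 1 of the 3 values shown sits, and the limit of > 222 nM in this assay, at which 1 of the 3 values shown sits, show. Compound 4 `Cc1cc(C#N)cc(C)c1Oc1nc(Nc2ccc(C#N)cc2)ncc1/C=C/C(=O)NC1CCN(C(=O)C(F)(F)F)CC1` differs from compound 1 by 1-((trifluoromethyl)carbonyl)piperidin-4-yl in place of propargyl on an amide-type nitrogen. With no readable step among the measured compounds and all three tolerated up to their limits, no change beyond the scatter is expected, and compound 4 is estimated in this assay at 300 nM, between 150 nM and 1000 nM, an expected step that the limit leaves unreadable from compound 1 to compound 4.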

Compound 4, half-maximal cytotoxic concentration: > 170 nM
Compound 4 was reported as a limit; the forecaster's own chance of this, stated with the estimate: 75%; the middle value does not contradict the limit.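

Compound 4, like compound 1, compound 2 and compound 3, is known only as a limit, so none of the steps to compound 4 can be read. The compounds shown leave open the actual value of any of the four in this assay.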